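Swapping the Aryl End of Compound 2

The source may hold more compounds than are shown below. What is called first, only, known or untested is meant among the compounds shown, and "the series" means these compounds.

Measured so far:
compound 1 `COc1ccc(C(=O)c2cc(OC)c(OC)c(OC)c2)cc1NC(=O)/C=C/c1ccc(OC)c(OC)c1` gives 6300 nM in a functional assay on B16 cells (Mus musculus) for cytotoxicity, read by MTT assay, with a stated time of 72 h; on this read-out lower numbers stand for stronger inhibition and higher numbers for weaker inhibition
compound 2 `COc1ccc(/C=C/C(=O)Nc2cc(C(=O)c3cc(OC)c(OC)c(OC)c3)ccc2OC)cc1` gives 8700 nM in this assay
compound 3 `C#CCOc1cccc(/C=C/C(=O)Nc2cc(C(=O)c3cc(OC)c(OC)c(OC)c3)ccc2OC)c1` gives 12200 nM in this assay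

Among these three numbers compound 2 stands second highest, and the steps of a 1.4-fold higher number from compound 1 to compound 2 (0.14 log units; within the scatter) and a 1.4-fold higher number from compound 2 to compound 3 (0.15 log units; within the scatter) are both within the scatter.

Compound 4 `COc1ccc(C(=O)c2cc(OC)c(OC)c(OC)c2)cc1NC(=O)/C=C/c1ccc(F)c(F)c1` has not been measured yet. It differs from compound 2 in one place: 3,4-difluorophenyl in place of 4-methoxyphenyl on a double-bonded chain carbon bound to a double-bonded chain carbon. The measured steps that bear on this change, each replacing the aryl group on the double-bonded chain carbon, are a 1.4-fold higher number from compound 2 to compound 3 (0.15 log units; within the scatter) and a 1.9-fold higher number from compound 1 to compound 3 (0.29 log units; within the scatter), both within the scatter. No step beyond the scatter is therefore expected in this assay, with at most a slight lean toward a higher number. Compound 4 is expected to give 10000 nM (range 4000 nM to 25000 nM), an expected step of a 1.1-fold higher number from compound 2 to compound 4 (0.06 log units; within the scatter).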

Compound 4, half-maximal inhibitory concentration: 6500 nM
For compound 4 the middle estimate is 1.5-fold (0.19 log units) above the measured one, and the stated range covers the measured number.
By their numbers in this assay, from the lowest: compounds 1, 4, 2 and 3 (each within the scatter of the next).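

In this assay, 3,4-difluorophenyl on the double-bonded chain carbon stays within the scatter of all three earlier aryl groups (4-methoxyphenyl: a 1.3-fold lower number from compound 2 to compound 4 (0.13 log units; within the scatter)), (3-(propargyloxy)phenyl: a 1.9-fold lower number from compound 3 to compound 4 (0.27 log units; within the scatter)) and (3,4-dimethoxyphenyl: a 1.0-fold higher number from compound 1 to compound 4 (0.01 log units; within the scatter)). Within the data shown here, this position therefore tolerates an aryl group without a hydrogen-bond acceptor as well as those carrying oxygen, with no step here beyond the scatter. Nothing available explains this flat result.

The compounds shown leave open whether an amine or a carboxylic acid on this aryl ring would move the number beyond the scatter. They also leave open what a longer chain in place of the ethenyl link would do.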